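The compounds below may be only part of what the source reports. "The series", "measured", "known", "first", "only" and "open" are said of these compounds alone.

Compound 1 `Cc1ccc(Cn2cc(CSc3nc(Nc4ccc(C)cc4)c(C#N)c(-c4ccccc4)n3)nn2)cc1`; compound 2 `Cc1ccc(Nc2nc(SCc3cn(Cc4ccccc4Cl)nn3)nc(-c3ccc(C(C)C)cc3)c2C#N)cc1`; compound 3 `COc1ccc(Nc2nc(SCc3cn(Cc4ccccc4Cl)nn3)nc(-c3ccc(C(C)C)cc3)c2C#N)cc1`.

In a functional assay on MCF7 cells (Homo sapiens) for inhibition, read by MTT assay, with a stated time of 72 h (on this read-out higher numbers stand for weaker inhibition and lower numbers for stronger inhibition), compound 2 gives 12200 nM. Compound 3 gives 10300 nM, and the step of a 1.2-fold lower number from compound 2 to compound 3 (0.07 log units; within the scatter). Compound 1 reaches only a limit of the assay, > 64000 nM. Compound 2 thus stands highest of the two numbers, with compound 3 within the scatter of it.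

Compound 4 `Cc1ccc(Nc2nc(SCc3cn(Cc4ccccc4Cl)nn3)nc(-c3ccc(Br)cc3)c2C#N)cc1` differs from compound 2 by bromo in place of isopropyl on an aromatic carbon. Going by the values given here, no measured step touches this group: the one measured step, a 1.2-fold lower number from compound 2 to compound 3 (0.07 log units; within the scatter), alters a different ring, and for compound 1 only the limit of > 64000 nM in this assay, at which 1 of the 3 values shown sits, is known. Compound 4 is therefore estimated at 15000 nM, expected between 5000 nM and 50000 nM. The expected step is a 1.2-fold higher number from compound 2 to compound 4 (0.09 log units; within the scatter), not beyond the scatter.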

Compound 4, half-maximal inhibitory concentration: 25100 nM
Beside the measured number, compound 4's estimate is 1.7-fold (0.22 log units) below it, and the stated range covers the measured number.
By their numbers in this assay, from the lowest: compounds 3 and 2 (each within the scatter of the next); then compound 4. At a limit, above all of these: compound 1.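

In this assay, putting bromo in place of isopropyl on this aromatic ring gives a 2.1-fold higher number from compound 2 to compound 4 (0.31 log units; beyond the scatter), the only step shown at this position. This position therefore responds to a change of group, although only modestly, and inhibition is weaker with bromo than with isopropyl. Nothing measured here explains why the number moves.

Only these two groups can be compared at this position. From the compounds shown here alone, how a fluoro, an amine or a carboxylic acid would read there stays open, as does whether any of them would give a clearly lower number than isopropyl.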